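A few compounds are considered here, and "the series" means these few. Any claim that something is new, unique, unknown or untested is made for them only; others in the source may bear on it.

Working notes on the trypsin series.

Three compounds have been run in an assay on isolated protein for inhibition of Trypsin (Homo sapiens) (on this read-out higher numbers stand for weaker inhibition and lower numbers for stronger inhibition), and all three returned a limit rather than a number. Compound 1 `CC(C(=O)c1cc(C(F)(F)F)nn1-c1ccc2onc(N)c2c1)c1ccc(-c2ccccc2S(C)(=O)=O)cc1F` gives > 20000 nM in this assay, a limit of the measurement. Compound 2 `CN(C)Cc1ccccc1-c1ccc(CC(=O)c2cc(C(F)(F)F)nn2-c2ccc3onc(N)c3c2)c(F)c1` gives > 4200 nM in this assay, again a limit. Compound 3 `CS(=O)(=O)c1ccccc1-c1ccc(CC(=O)c2cc(C(F)(F)F)nn2-c2ccc3onc(N)c3c2)cc1` gives > 20000 nM in this assay, also a limit. Compound 3 therefore sits at the limit of > 20000 nM in this assay, at which 2 of the 3 values shown sit, the same limit as compound 1, while compound 2 sits at the limit of > 4200 nM in this assay, at which 1 of the 3 values shown sits; none of the three shows a measurable inhibition constant, so no order among them can be read from these numbers.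

Compound 4 `CS(=O)(=O)c1ccccc1-c1ccc(CC(=O)c2cc(C(F)(F)F)nn2-c2ccc3onc(N)c3c2)c(F)c1` is the next member and has not been measured in this assay. Against compound 3 the change is fluoro in place of hydrogen on an aromatic carbon. The fluoro enters on an aromatic carbon of a six-membered aromatic ring of carbon only, ortho to a large group and meta to the 2-(methylsulfonyl)phenyl group; the rest of the molecule is unchanged.

Among the compounds with values here, with compound 3 at a limit and no measured step anywhere in the set, no shift beyond the scatter is expected from compound 3 to compound 4, the estimated step being a step that the limit leaves unreadable from compound 3 to compound 4. Compound 4 is expected to give 30000 nM in this assay, within 10000 nM to 100000 nM, most likely reported again as a limit.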

Compound 4, inhibition constant: > 20000 nM
Compound 4 was reported as a limit; the forecaster's own chance of this, stated with the estimate: 85%; the middle value is on the limit's open side.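

Compound 4 returned a limit, as did compound 1, compound 2 and compound 3, so none of the steps from those three to compound 4 can be read in this assay. The compounds shown leave open how large the inhibition constant of any member is, and whether fluoro in place of hydrogen changes it at all.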